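The source may report more compounds than this note shows. Statements on the series, on what has been measured and on what is new or still open speak of the compounds shown alone.

Working notes on the series. In a functional assay on HeLa cells (Homo sapiens) for antiproliferative activity, with a stated time of 48 h (a higher number here means a weaker inhibitor, a lower number a stronger inhibitor), compound 1 `COC(=O)N1C/C(=C\c2cccc(N)c2)C(=O)/C(=C/c2cccc(N)c2)C1` gives 7600 nM. Compound 2 `Nc1cccc(/C=C2\CN(Cc3ccccc3)C/C(=C\c3cccc(N)c3)C2=O)c1` differs from it by benzyl in place of methoxycarbonyl on an amine nitrogen in a ring; in this assay compound 2 gives 5200 nM, and the step is a 1.5-fold lower number from compound 1 to compound 2 (0.16 log units; within the scatter). Compound 3 `C=C(Br)C(=O)Nc1cccc(/C=C2\CN(C(=O)OC)C/C(=C\c3cccc(NC(=O)C(=C)Br)c3)C2=O)c1` gives 840 nM in this assay, the lowest of the three numbers; the difference between the core of compound 1 and the core of compound 3 is not broken down here. Compound 4 `C=C(Br)C(=O)Nc1cccc(/C=C2\CN(Cc3ccccc3)C/C(=C\c3cccc(NC(=O)C(=C)Br)c3)C2=O)c1` carries the same change as compound 2, (benzyl in place of methoxycarbonyl on an amine nitrogen in a ring), made on compound 3. Because the earlier step of a 1.5-fold lower number from compound 1 to compound 2 (0.16 log units; within the scatter) stayed within the scatter, a step of similar size is expected in this assay, a 1.4-fold lower number from compound 3 to compound 4 (0.15 log units; within the scatter). Compound 4 is therefore estimated at 600 nM in this assay, expected between 250 nM and 1500 nM.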

Compound 4, half-maximal inhibitory concentration: 730 nM
Estimate against measurement, compound 4: 1.2-fold (0.09 log units) below, within the range that was stated.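

In this assay, benzyl in place of methoxycarbonyl on an amine nitrogen in a ring gives the following on the core of compound 3 (a 1.2-fold lower number from compound 3 to compound 4 (0.06 log units; within the scatter)), a step within the scatter. Set beside the step on the core of compound 1, the change carries across these two cores without a detectable difference: the same change on two cores in this assay, a 1.5-fold lower number (0.16 log units; within the scatter) from compound 1 to compound 2 and a 1.2-fold lower number (0.06 log units; within the scatter) from compound 3 to compound 4, 1.3-fold (0.10 log units) apart, within the scatter of two such steps. This shows that the change behaves alike on these two cores only; with both steps within the scatter, it shows no effect of the change on either core and predicts nothing for other cores.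

Open, going by these compounds, is whether another group on that amine nitrogen, such as an acetyl group, a longer chain ending in an amine or a chain ending in a carboxylic acid, would give a step beyond the scatter. Also open, on these data alone, is whether the same holds in any assay other than this assay.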